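A few compounds are considered here, and "the series" means these few. Any claim that something is new, unique, unknown or untested is made for them only; others in the source may bear on it.

Measured so far:
compound 1 `Cc1ccc(S(=O)(=O)c2n[nH]c3ccc(N4CCN(C)CC4)cc23)cc1` — 112 nM
compound 2 `CC(C)Cn1nc(S(=O)(=O)c2cccc3ccccc23)c2cc(N3CCN(C)CC3)ccc21` — 1.4 nM

In a functional assay on HeLa cells for antagonist activity at 5-hydroxytryptamine receptor 6 (Homo sapiens) (on this read-out higher numbers stand for weaker inhibition and lower numbers for stronger inhibition), compound 1 gives 112 nM, the highest of the two numbers recorded; compound 2 gives 1.4 nM, a far lower number, beyond the scatter. The two differ in more than one place, so no single step can be read from them.

Compound 3 `CN1CCN(c2ccc3[nH]nc(S(=O)(=O)c4c(Cl)cccc4Cl)c3c2)CC1` carries 2,6-dichlorophenyl in place of 4-methylphenyl on a sulfonyl sulfur. Within the data shown here, no measured pair shows this change, so its size is unknown. Compound 3 is expected at 60 nM, within 15 nM to 250 nM; the estimated step of a 1.9-fold lower number from compound 1 to compound 3 (0.27 log units; within the scatter) is a modest lowering, possibly not beyond the scatter.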

Compound 3, half-maximal inhibitory concentration: 40 nM
For compound 3 the middle estimate is 1.5-fold (0.18 log units) above the measured one; measured number inside the range.
By their numbers in this assay, from the lowest: compound 2; then compound 3; then compound 1.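

In this assay the exchange of 4-methylphenyl for 2,6-dichlorophenyl on a sulfonyl sulfur gives a 2.8-fold lower number from compound 1 to compound 3 (0.45 log units; beyond the scatter) with the rest of the core of compound 1 unchanged. Among these compounds, this is the first single-place reading, and it shows that the aryl group on this sulfonyl sulfur affects the read-out. Nothing shown explains the step.

Open, from the compounds shown here alone, is whether 2-chlorophenyl, with one chlorine, or a pyridine ring would give a similar step here. Also open, going by these compounds, is how much of the low number of compound 2 comes from its sulfonyl group, since it differs from compound 1 in more than one place.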